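Swapping an aryl amine for a pyrrolidine on the core

The source may hold more compounds than are shown below. What is called first, only, known or untested is meant among the compounds shown, and "the series" means these compounds.

Compound 1 `COc1ccc2c(c1)NC(=O)CN2c1nc(Nc2cccc(C#N)c2)nc2ccccc12` carries a (3-cyanophenyl)amino group on the shared core. In a functional assay on KB cells (Homo sapiens) for inhibition, read by sulforhodamine B assay, with a stated time of 48 h (on this read-out higher numbers stand for weaker inhibition of growth and lower numbers for stronger inhibition of growth), compound 1 gives 61.5 nM, the highest number of the three measured compounds, so it is the weakest of them. Compound 2 `COc1ccc2c(c1)NC(=O)CN2c1nc(NCCCO)nc2ccccc12` gives 4.92 nM and compound 3 `COc1ccc2c(c1)NC(=O)CN2c1nc(NC2CC2)nc2ccccc12` gives 2.11 nM. The steps of a 13-fold lower number from compound 1 to compound 2 (1.10 log units; beyond the scatter) and a 29-fold lower number from compound 1 to compound 3 (1.46 log units; beyond the scatter) show that groups without an aromatic ring on this nitrogen lower the number strongly; between them, a 2.3-fold lower number from compound 2 to compound 3 (0.37 log units; beyond the scatter). Compound 4 `COc1ccc2c(c1)NC(=O)CN2c1nc(N2CCCC2)nc2ccccc12` differs from compound 1 thus: pyrrolidin-1-yl in place of (3-cyanophenyl)amino on an aromatic carbon. The entering group lacks an aromatic ring, like those of compounds 2 and 3, but brings no hydrogen-bond donor, which neither of them tests. A lower number is therefore expected, with less certainty. For compound 4 the estimate is 8 nM (range 2 nM to 40 nM), an expected step of a 7.7-fold lower number from compound 1 to compound 4 (0.89 log units; beyond the scatter).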

Compound 4, concentration for 50% growth inhibition: 33.2 nM
For compound 4 the middle estimate is 4.2-fold (0.62 log units) below the measured one; low and high end bracket the measured number.
By their numbers in this assay, from the lowest: compound 3; then compound 2; then compounds 4 and 1 (each within the scatter of the next).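

Taking away the aromatic ring is not enough on its own at this position: in this assay the pyrrolidin-1-yl group gives almost the same result as the (3-cyanophenyl)amino group (a 1.9-fold lower number from compound 1 to compound 4 (0.27 log units; within the scatter)). The ring-free groups also differ widely from one another (a 16-fold higher number from compound 3 to compound 4 (1.20 log units; beyond the scatter); a 6.7-fold higher number from compound 2 to compound 4 (0.83 log units; beyond the scatter)), and although compounds 2 and 3 keep the hydrogen on the attached nitrogen, compound 1 keeps it too, so that hydrogen alone does not set the number. No measurement available here explains these gaps.

Going by these compounds, whether a dimethylamino group would behave like pyrrolidin-1-yl remains open. So does the effect of a piperidine or morpholine ring.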